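This account rests on a few compounds, and the source may have more. Where it says the series, first, only, none or still open, it means among the compounds named here.

Measured compounds:
Compound 1, `Cc1ccnc([C@@H](C)Oc2cc3oc(=O)n(CCC(=O)O)c3cc2Cl)c1`: in a physicochemical assay for permeability, using PAMPA (on this read-out higher numbers stand for higher permeability and lower numbers for lower permeability), compound 1 gives < 3 nm/s, which is a limit of the assay and not a number.
Compound 2, `O=C(O)CCn1c(=O)oc2cc(OCc3ccccn3)c(Cl)cc21`: in this assay compound 2 gives 11 nm/s.
Compound 3, `Cc1ccc([C@@H](C)Oc2cc3oc(=O)n(CCC(=O)O)c3cc2Cl)nc1`: in this assay compound 3 gives 22 nm/s.

Within the data shown here, compound 1 stands at the floor of the series, being the one compound sitting at the limit of < 3 nm/s in this assay, at which 1 of the 3 values shown sits. Compound 2 and compound 3 both give numbers and lie within the scatter of one another. Compound 4, `C[C@@H](Oc1cc2oc(=O)n(CCC(=O)O)c2cc1Cl)c1ncccn1`, is not yet measured; relative to compound 1 it carries pyrimidin-2-yl in place of 4-methylpyridin-2-yl on a saturated chain carbon bound to an oxygen on an aromatic ring and a saturated chain carbon. Among the measured compounds shown here, only one measured step acts at the same position: an at least 7.3-fold higher number from compound 1 to compound 3 (0.86 log units; beyond the scatter). For the measured compounds named here, that step keeps the same ring and shifts only a methyl, whereas the change to compound 4 exchanges the ring and drops the methyl, for which no measured step exists. The starting value of compound 1 is itself only a limit, so the step to compound 4 is expected to be a number no lower from compound 1 to compound 4 (the limit leaves the size open), with no clear movement beyond the scatter. Compound 4 is therefore estimated at 3 nm/s in this assay, within a range of 1 nm/s to 10 nm/s.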

Compound 4, apparent permeability: < 3 nm/s
Compound 4: a limit, no number; the forecaster's own chance of this, stated with the estimate: 55%; the middle value sits exactly at the limit.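

In this assay compound 4 gives < 3 nm/s, which is a limit and not a number, so a second group at this position now sits at the floor of the series: the limit of < 3 nm/s in this assay, at which 2 of the 4 values shown sit.

Pyrimidin-2-yl in place of 5-methylpyridin-2-yl gives an at least 7.3-fold lower number from compound 3 to compound 4 (0.86 log units; beyond the scatter), showing that exchanging the ring at this position can take the read-out from a measurable number down to the limit, just as moving the methyl did. The second readable step is an at least 3.6-fold lower number from compound 2 to compound 4 (0.56 log units; beyond the scatter), and the remaining step, between the two compounds at the limit, cannot be read.

As far as these compounds go, the true values of compound 1 and compound 4 stay open, so 4-methylpyridin-2-yl and pyrimidin-2-yl cannot be ranked against each other. Also open, from the compounds shown here alone, is how a phenyl ring, or a pyridin-2-yl carrying a methoxy group, would read at this position.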